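This account rests on a few compounds, and the source may have more. Where it says the series, first, only, none or still open, it means among the compounds named here.

The series shares one core, shown in compound 1 `COc1cc2c(cc1OC)C(CC(N)=O)CC2`, which carries an unsubstituted amide. In a functional assay on the whole organism (strain Wistar) for inhibition, with Rattus norvegicus as the target, read by paw edema, with stated times of 60 min and 24 h, at a dose of 100 mg/kg by the oral route (on this read-out higher numbers stand for more inhibition at the one dose given (going by the name of the read-out) and lower numbers for less inhibition), compound 1 gives 26.7%. Compound 2 `CCCNC(=O)CC1CCc2cc(OC)c(OC)cc21` bears propyl on the amide nitrogen, and compound 2 gives 26.7%; no change at the digits printed from compound 1 to compound 2 (within the scatter). Compound 3 `COc1cc2c(cc1OC)C(CC(=O)NC1CCCC1)CC2` bears cyclopentyl there, and compound 3 gives 46.7%, the highest of the three numbers: a number 20 percentage points higher from compound 1 to compound 3 (beyond the scatter), and likewise a number 20 percentage points higher from compound 2 to compound 3 (beyond the scatter). Compound 4 `COc1cc2c(cc1OC)C(CC(=O)N1CCCCC1)CC2` differs from compound 3 in one place: piperidin-1-yl in place of cyclopentylamino on a carbonyl carbon. The measured steps all vary the group on the amide nitrogen while its hydrogen stays; none of them removes that hydrogen, so they bear on this change only loosely. On these data alone, the gain in a number 20 percentage points higher from compound 2 to compound 3 (beyond the scatter) shows that the number is higher with a ring carried by the nitrogen, but whether the donor matters is untested. A step of a number 11.7 percentage points lower from compound 3 to compound 4 (beyond the scatter) is therefore expected, near no change or a modest fall. Compound 4 is estimated at 35%, with a range from 15% to 55%.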

Compound 4, a percentage reported as inhibition, in the whole organism at one dose (the size of the read-out at that dose, not a potency): 40%
For compound 4 the middle estimate is 5 percentage points below the measured one; the range from low to high includes it.
By their numbers in this assay, from the lowest: compounds 1 and 2 (each within the scatter of the next); then compounds 4 and 3 (each within the scatter of the next).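

In this assay, moving from cyclopentylamino to piperidin-1-yl on the carbonyl carbon removes the amide hydrogen, and the outcome is a number 6.7 percentage points lower from compound 3 to compound 4 (within the scatter), so at this dose the read-out does not depend measurably on that hydrogen-bond donor. The ring-bearing amide without the donor also keeps its advantage over the two simpler amides, with a number 13.3 percentage points higher from compound 2 to compound 4 (beyond the scatter) and a number 13.3 percentage points higher from compound 1 to compound 4 (beyond the scatter). No measurement offered here explains these results.

This step also changes the ring and how it is attached, so the loss of the donor cannot be separated from those changes. On these data alone, whether morpholin-4-yl, pyrrolidin-1-yl or an open-chain diethylamino group on the same carbonyl carbon would give a similar number remains open.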